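The source may hold more compounds than are shown below. What is called first, only, known or untested is meant among the compounds shown, and "the series" means these compounds.

In an ADME assay on NIH3T3 cells (Mus musculus) for cytotoxicity, read by XTT assay, with a stated time of 24 h (a higher number here means a weaker inhibitor, a lower number a stronger inhibitor), compound 1, `Cn1nnnc1SCC(=O)N/N=C/c1ccc([N+](=O)[O-])cc1`, gives 9300000 nM, and compound 2, `Cn1nnnc1SCC(=O)N/N=C/c1ccc(F)cc1`, gives 10000000 nM. The change between them is fluoro in place of nitro on an aromatic carbon, and the step it made was a 1.1-fold higher number from compound 1 to compound 2 (0.03 log units; within the scatter). Compound 3, `Cn1nnnc1SCC(=O)N/N=C/c1ccccc1[N+](=O)[O-]`, gives 2020000 nM in this assay; the difference between its core and that of compound 1 is not broken down here. Compound 4, `Cn1nnnc1SCC(=O)N/N=C/c1ccccc1F`, has not yet been measured in this assay. It differs from compound 3 by fluoro in place of nitro on an aromatic carbon, which is the same kind of change as that from compound 1 to compound 2, but here the fluoro stands ortho to a large group rather than para to it. Because the earlier step was a 1.1-fold higher number from compound 1 to compound 2 (0.03 log units; within the scatter), compound 4 is expected to show a step of about a 1.2-fold higher number from compound 3 to compound 4 (0.09 log units; within the scatter), and its estimated value is 2500000 nM.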

Compound 4, half-maximal inhibitory concentration: 2000000 nM
Beside the measured number, compound 4's estimate is 1.3-fold (0.10 log units) above it, and the stated range covers the measured number.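

In this assay, the new step is a 1.0-fold lower number from compound 3 to compound 4 (0.00 log units; within the scatter), so fluoro in place of nitro on an aromatic carbon again produces no change beyond the scatter. The step on this second core agrees with the earlier one: the same change on two cores in this assay, a 1.1-fold higher number (0.03 log units; within the scatter) from compound 1 to compound 2 and a 1.0-fold lower number (0.00 log units; within the scatter) from compound 3 to compound 4, 1.1-fold (0.04 log units) apart, within the scatter of two such steps. This shows that the change carried over between these two cores. Going by these compounds alone, with only two pairs, it does not show that it would do so on any other core.

The compounds shown leave open whether an amine, a carboxylic acid or a methoxy group at the same aromatic carbon would match nitro and fluoro. They also leave open whether a longer chain on the tetrazole-free part of the shared core would alter this result.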